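This account rests on a few compounds, and the source may have more. Where it says the series, first, only, none or still open, it means among the compounds named here.

Series notes. The shared core of compound 1 `COc1ccc(/C=C\c2cc(OC)c(OC)c(OC)c2)cc1OCc1ccc(CN[C@H](C(=O)O)[C@H](C)O)cc1` carries, on a saturated chain carbon bound to an aromatic carbon, a (1-carboxy-2-hydroxypropyl)amino group; compound 2 `COc1ccc(/C=C\c2cc(OC)c(OC)c(OC)c2)cc1OCc1ccc(CN2CC[C@@H](O)C2)cc1` carries a 3-hydroxypyrrolidin-1-yl there and compound 3 `COc1ccc(/C=C\c2cc(OC)c(OC)c(OC)c2)cc1OCc1ccc(CN2CC[C@@H](C(=O)O)C2)cc1` a 3-carboxypyrrolidin-1-yl. In an ADME assay on HEK293 cells (Homo sapiens) for cytotoxicity, read by CCK-8 assay, with a stated time of 48 h (a higher number here means a weaker inhibitor, a lower number a stronger inhibitor), compound 1 gives > 50000 nM, a limit of the assay and not a number. Compound 2 likewise gives > 50000 nM, also a limit. For the measured compounds named here, compound 3 gives 27000 nM, the only number among the three. The step from compound 1 to compound 2 is a step that the two limits leave unreadable from compound 1 to compound 2. The other two steps are an at least 1.8-fold lower number from compound 1 to compound 3 (0.26 log units; that floor lies within the scatter) and an at least 1.8-fold lower number from compound 2 to compound 3 (0.26 log units; that floor lies within the scatter), both floors within the scatter; the reason they are floors is the limit of > 50000 nM in this assay, at which 2 of the 3 values shown sit.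

Compound 4 `COc1ccc(/C=C\c2cc(OC)c(OC)c(OC)c2)cc1OCc1ccc(CNCCNC(C)=O)cc1` is next: (2-acetamidoethyl)amino in place of 3-carboxypyrrolidin-1-yl on a saturated chain carbon bound to an aromatic carbon. Going by the values given here, this change replaces the one group that went with the single numeric reading. Both measured steps into compound 3 came from compounds at the limit, so the expectation is a move back toward that limit, an upward number, though each of those steps was itself within the scatter. Compound 4 is expected at 45000 nM, with a range of 20000 nM to 120000 nM. The step is expected to be a 1.7-fold higher number from compound 3 to compound 4 (0.22 log units; within the scatter), a rise that may end at the limit.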

Compound 4, half-maximal inhibitory concentration: > 50000 nM
Compound 4: only a limit was reported (the forecaster's own chance of this, stated with the estimate: 55%); middle value at least 1.1-fold (0.04 log units) away from the limit.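

For the compounds shown here, exchanging 3-carboxypyrrolidin-1-yl for (2-acetamidoethyl)amino on a saturated chain carbon bound to an aromatic carbon gives, in this assay, an at least 1.8-fold higher number from compound 3 to compound 4 (0.26 log units; that floor lies within the scatter), so the open chain joins the ring-bearing and ring-free groups already read at the limit, and compound 3 remains the only compound with a number. A carboxy group alone does not go with a numeric reading at this place, as compound 1 also carries one and reads at the limit, while compound 2 and compound 4 have none and read the same way; the steps among compound 1, compound 2 and compound 4 cannot be read. Every size in this set is therefore either a floor or unreadable because of a single ceiling: the limit of > 50000 nM in this assay, at which 3 of the 4 values shown sit.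

From the compounds shown here alone, whether compound 3 truly stands apart from the other three remains open, as its printed floors all lie within the scatter. Also open, going by these compounds, is how a carboxylic acid on a longer open chain, or a simple primary amine, would read at this place, and whether either would give a number rather than a limit.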